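Amine to Reversed Amide on a Long Chain

The source may hold more compounds than are shown below. What is called first, only, known or untested is meant among the compounds shown, and "the series" means these compounds.

Measured in a functional assay (RXF 631 cells, Homo sapiens) for inhibition, read by sulforhodamine B assay, with a stated time of 48 h; a higher number here means a weaker inhibitor of growth, a lower number a stronger inhibitor of growth:
- compound 1 `CCCCCCCCCCCC[C@@H](O)[C@H]1CC[C@H]([C@H](O)CCCCCCCCCCNC(=O)c2ccnn2C)O1` gives 100000 nM
- compound 2 `CCCCCCCCCCCC[C@@H](O)[C@H]1CC[C@H]([C@H](O)CCCCCCCCCCNCc2ccnn2C)O1` gives 2400 nM

Of the two measured compounds, compound 2 holds the lower number, at 2400 nM. Compound 3 `CCCCCCCCCCCC[C@@H](O)[C@H]1CC[C@H]([C@H](O)CCCCCCCCCCC(=O)Nc2ccnn2C)O1` has not yet been measured. It alters compound 2 as follows: (1-methyl-1H-pyrazol-5-yl)carbamoyl in place of ((1-methyl-1H-pyrazol-5-yl)methyl)amino on a saturated chain carbon, ten or more bonds along the chain from an oxygen on a saturated carbon and a saturated ring carbon.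

Among the compounds with values here, only one measured step bears on this change. It is a 42-fold lower number from compound 1 to compound 2 (1.62 log units; beyond the scatter), a large step that removes a carbonyl. Within the data shown here, compound 3 regains a carbonyl, though no measured compound carries its (1-methyl-1H-pyrazol-5-yl)carbamoyl group. A large move to a higher number in this assay is therefore expected, probably short of the full distance to compound 1 at 100000 nM.

The expected change is a 13-fold higher number from compound 2 to compound 3 (1.10 log units; beyond the scatter). The estimate for compound 3 is 30000 nM, with an expected range of 7000 nM to 100000 nM.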

Compound 3, concentration for 50% growth inhibition: 100000 nM
The estimate for compound 3 lay 3.3-fold (0.52 log units) below the measured number; the range from low to high includes it.
By their numbers in this assay, from the lowest: compound 2; then compounds 1 and 3 (each within the scatter of the next).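

In this assay, the change shows a 42-fold higher number from compound 2 to compound 3 (1.62 log units; beyond the scatter), so the carbamoyl group on this chain cancels all of the advantage that the amine held over the first amide. Turning the amide around makes no difference that can be read, with no change at the digits printed from compound 1 to compound 3 (within the scatter); among these three compounds, only compound 2, the one with the amine, stands apart, and neither amide orientation goes against that. Nothing measured here accounts for the difference between the amine and the two amides.

The compounds shown leave open whether a urea or a sulfonamide at this place on the chain would read like the two amides or like compound 2. They also leave open whether an N-methyl tertiary amine would keep the number of compound 2, and whether a shorter chain would alter the gap between amine and amide.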